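The compounds below may be only part of what the source reports. "The series", "measured", "known", "first", "only" and "open" are said of these compounds alone.

Compound 1 `Cc1ccc(NC(=S)NC(=O)c2ccc(OCc3cccc(Cl)c3)cc2)cc1-c1nc2ccccc2[nH]1` gives 51300 nM in a functional assay on MGC-803 cells (Homo sapiens) for inhibition, read by MTT assay, with a stated time of 48 h; a lower number here means a stronger inhibitor, a higher number a weaker inhibitor. Compound 2 `Cc1ccc(NC(=S)NC(=O)c2ccc(OCc3cccc(Cl)c3Cl)cc2)cc1-c1nc2ccccc2[nH]1` returns only a limit of this assay, > 100000 nM. For the measured compounds named here, the step of an at least 1.9-fold higher number from compound 1 to compound 2 (0.28 log units; that floor lies within the scatter) is the only measured change in the same part of the molecule. Compound 3 `Cc1ccc(NC(=O)NC(=O)c2ccc(OCc3ccccc3F)cc2)cc1-c1nc2ccccc2[nH]1` gives 2520 nM, the lowest of the two numbers shown, and its nearest neighbour, compound 1, sits well beyond the scatter from it. Compound 4 `Cc1ccc(NC(=O)NC(=O)c2ccc(OCc3ccc(F)cc3)cc2)cc1-c1nc2ccccc2[nH]1` differs from compound 3 in one place: 4-fluorophenyl in place of 2-fluorophenyl on a saturated chain carbon bound to an oxygen on an aromatic ring. Going by the values given here, no measured step shifts a fluorine within this ring, so nothing bears directly on the change, and the one measured step nearby was small. A step of about a 1.0-fold lower number from compound 3 to compound 4 (0.00 log units; within the scatter) is therefore expected, none beyond the scatter. Compound 4 is estimated at 2500 nM, between 1000 nM and 6500 nM.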

Compound 4, half-maximal inhibitory concentration: 160 nM
For compound 4 the middle estimate is 16-fold (1.19 log units) above the measured one, and the stated range ends above it.
By their numbers in this assay, from the lowest: compound 4; then compound 3; then compound 1. At a limit, above all of these: compound 2.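

In this assay, the 2-fluorophenyl to 4-fluorophenyl change gives a 16-fold lower number from compound 3 to compound 4 (1.20 log units; beyond the scatter). For the compounds shown here, the two compounds have the same atoms, so moving a single fluorine can alter the result strongly, which the earlier compounds did not show: the only earlier step in this part of the molecule, an at least 1.9-fold higher number from compound 1 to compound 2 (0.28 log units; that floor lies within the scatter), added a chloro and has a floor within the scatter. Nothing measured here explains why the fluorine's place matters.

On these data alone, it remains open whether a chloro group, a methoxy group or an amine in place of the fluorine would give a similar number.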